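A Second Hydroxy Group on the 2-Hydroxyphenyl Ring

A few compounds are considered here, and "the series" means these few. Any claim that something is new, unique, unknown or untested is made for them only; others in the source may bear on it.

Of the compounds shown here, two sharing one core have been measured in an ADME assay on WI-38 cells (Homo sapiens) for cytotoxicity, read by MTT assay, with a stated time of 48 h; on this read-out higher numbers stand for weaker inhibition and lower numbers for stronger inhibition. Compound 1 `COc1ccc(/C=N/c2cc3ccccc3nc2-c2ccccc2F)c(O)c1` carries a methoxy group and gives 30500 nM. Compound 2 `Oc1ccccc1/C=N/c1cc2ccccc2nc1-c1ccccc1F` lacks that methoxy, and in this assay compound 2 gives 33300 nM. The single step between them, a 1.1-fold higher number from compound 1 to compound 2 (0.04 log units; within the scatter), lies within the scatter, so on the numbers shown compound 2 stands level with compound 1, the only other compound measured.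

Compound 3 `Oc1cccc(/C=N/c2cc3ccccc3nc2-c2ccccc2F)c1O` is compound 2 with hydroxy in place of hydrogen on an aromatic carbon, which turns 2-hydroxyphenyl into 2,3-dihydroxyphenyl. Among the measured compounds shown here, the one measured step bears on this change only loosely, since it concerns the removal of a methoxy rather than the entry of a hydroxy, and it was within the scatter. Nothing in the data points to a shift in either direction. Compound 3 is therefore expected to give about 33000 nM, with a range from 15000 nM to 70000 nM, so that the expected step of a 1.0-fold lower number from compound 2 to compound 3 (0.00 log units; within the scatter) is no larger than the scatter.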

Compound 3, half-maximal inhibitory concentration: > 40000 nM
Compound 3 was reported as a limit (the forecaster's own chance of this, stated with the estimate: 20%); middle value at least 1.2-fold (0.08 log units) away from the limit.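

In this assay compound 3 is reported only as a limit of the assay, not as a number: the limit of > 40000 nM in this assay, at which 1 of the 3 values shown sits. Even so, this is the first compound shown with a hydroxy group entering the ring, at a place ortho to a hydroxy group and meta to a large group, and the step reads an at least 1.2-fold higher number from compound 2 to compound 3 (0.07 log units; that floor lies within the scatter), while the wider change from 2-hydroxy-4-methoxyphenyl to 2,3-dihydroxyphenyl reads an at least 1.3-fold higher number from compound 1 to compound 3 (0.11 log units; that floor lies within the scatter). The earlier pair concerned only a methoxy group, whereas these steps show that a second hydroxy group at this place gives no sign of stronger inhibition, although both floors lie within the scatter, so a real change in the other direction can be neither claimed nor excluded.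

On these data alone, the true number for compound 3 remains unknown, so how far it lies from the values of compound 1 and compound 2 stays open. Also open, as far as these compounds go, is whether a different group at this same place, such as an amine, a carboxylic acid or a methoxy group, would move the number in either direction.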